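From chloro to fluoro on compound 2

A few compounds are considered here, and "the series" means these few. Any claim that something is new, unique, unknown or untested is made for them only; others in the source may bear on it.

Compound 1 `COc1ccc(Nc2nc(Nc3cc(C)[nH]n3)cc(N3CCN(C)CC3)n2)cc1OC`: 6540 nM
Compound 2 `Cc1cc(Nc2cc(N3CCN(C)CC3)nc(Nc3ccc(F)c(Cl)c3)n2)n[nH]1`: 213 nM

In a functional assay on MCF7 cells (Homo sapiens) for antiproliferative activity, read by CCK-8 assay, with a stated time of 48 h (on this read-out higher numbers stand for weaker inhibition and lower numbers for stronger inhibition), compound 2 holds the lower of the two numbers, 213 nM. Compound 3 `Cc1cc(Nc2cc(N3CCN(C)CC3)nc(Nc3ccc(F)c(F)c3)n2)n[nH]1` has fluoro in place of chloro on an aromatic carbon, ortho to a fluoro group: fluoro in place of chloro on an aromatic carbon. Among the compounds with values here, only one measured step bears on this, a 31-fold lower number from compound 1 to compound 2 (1.49 log units; beyond the scatter). That large step exchanged 3,4-dimethoxyphenyl for 3-chloro-4-fluorophenyl, a much wider change, so it sets no size here. A small step toward a higher number, if any, is therefore expected: a 1.6-fold higher number from compound 2 to compound 3 (0.22 log units; within the scatter). The estimate for compound 3 is 350 nM, with an expected range of 110 nM to 1100 nM.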

Compound 3, half-maximal inhibitory concentration: 1290 nM
Estimate against measurement, compound 3: 3.7-fold (0.57 log units) below; the measured number lies above the stated range.
By their numbers in this assay, from the lowest: compound 2; then compound 3; then compound 1.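

In this assay this single position proves sensitive: fluoro in place of chloro, one heavy atom for one heavy atom, gives a 6.1-fold higher number from compound 2 to compound 3 (0.78 log units; beyond the scatter) and so costs far more than a small swap might suggest. The 3,4-difluorophenyl group still keeps part of the gain over 3,4-dimethoxyphenyl, with a 5.1-fold lower number from compound 1 to compound 3 (0.70 log units; beyond the scatter) across that wider change, so the chloro accounts for only part of the earlier large step. No measurement here gives a reason for this loss.
Still open, on these data alone, is how a bromo group or a trifluoromethyl group would read on this same aromatic carbon, and whether the order seen for chloro and fluoro would continue.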